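Series notes: diaryl ether chain analogues, maximal response

The source may hold more compounds than are shown below. What is called first, only, known or untested is meant among the compounds shown, and "the series" means these compounds.

Measured compounds:
compound 1 `COC(=O)c1ccc(OCCCCOc2ccc(C(=O)CC3CCCC3)c(O)c2C)cc1` — 12.2%
compound 2 `COC(=O)c1ccc(OCCCCOc2ccc(C(=O)CC3CCCC3)c(C)c2C)cc1` — 14.1%
compound 3 `COC(=O)c1ccc(OCCCCOc2ccc(C(=O)CC(C)C)c(O)c2C)cc1` — 16.4%

In an assay on HEK293 cells for positive allosteric modulation of metabotropic glutamate receptor 2 (Rattus norvegicus), read by thallium flux, with a stated time of 2.5 min (on this read-out higher numbers stand for larger maximal responses and lower numbers for smaller maximal responses), compound 1 gives 12.2%, the lowest of the three numbers, though its companions sit within the scatter of it: a number 1.9 percentage points higher from compound 1 to compound 2 (within the scatter) and a number 4.2 percentage points higher from compound 1 to compound 3 (within the scatter). Neither change moves the read-out beyond noise.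

Compound 4 `Cc1c(OCCCCOc2ccc(C(=O)O)c(Cl)c2)ccc(C(=O)CC2CCCC2)c1O` is not yet measured. It differs from compound 1 in one place: 4-carboxy-3-chlorophenyl in place of 4-(methoxycarbonyl)phenyl on an oxygen on a saturated carbon. Within the data shown here, the two measured steps touch other parts of the shared core of compound 1, namely the aromatic carbon carrying hydroxy or methyl and the saturated chain carbon bound to a carbonyl carbon; neither concerns the group on an oxygen on a saturated carbon, so no measured step bears on this change. Among the measured compounds shown here, the only guide is that all three measured compounds sit close together at a low maximal response.

Compound 4 is therefore expected near compound 1, with the step estimated as a number 1.8 percentage points higher from compound 1 to compound 4 (within the scatter). The estimate for compound 4 is 14%, with a range from 4% to 30%, the width reflecting the absence of any measured step at this position.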

Compound 4, largest response reached (reported as percent of maximum), in percent of the reference or control that the assay uses: 80.8%
The estimate for compound 4 lay 66.8 percentage points below the measured number, outside the stated range (above it).
By their numbers in this assay, from the lowest: compounds 1, 2 and 3 (each within the scatter of the next); then compound 4.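

With 4-carboxy-3-chlorophenyl in place of 4-(methoxycarbonyl)phenyl on an oxygen on a saturated carbon, this assay gives a number 68.6 percentage points higher from compound 1 to compound 4 (beyond the scatter). Among these compounds, this group is the first place where one change moves the maximal response beyond the scatter, whereas the changes at the aromatic carbon carrying hydroxy or methyl and at the saturated chain carbon bound to a carbonyl carbon did not. Nothing at hand accounts for the size of this step.

As far as these compounds go, the change brings in the carboxylic acid and the chlorine together, so the share of each stays open, and a plain 4-carboxyphenyl group would help separate them. Also open, from the compounds shown here alone, is whether methyl in place of hydroxy, or isopropyl in place of cyclopentyl, stays within the scatter when 4-carboxy-3-chlorophenyl is present.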